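Fluoro for hydrogen, repeated on a second core

The compounds below may be only part of what the source reports. "The series", "measured", "known", "first", "only" and "open" are said of these compounds alone.

In an assay on isolated protein for inhibition of Rho-associated protein kinase 1 (Homo sapiens), tested at 30 uM (on this read-out higher numbers stand for more inhibition at the one concentration tested (going by the name of the read-out) and lower numbers for less inhibition), compound 1 `Cn1cnc2c(Sc3ccccc3)ncnc21` gives 6%. Compound 2 `Cn1cnc2c(Sc3ccc(F)cc3)ncnc21` differs from it by one change, (fluoro in place of hydrogen on an aromatic carbon), and in this assay compound 2 gives 6%, so that no change at the digits printed from compound 1 to compound 2 (within the scatter). Compound 3 `Clc1ncnc2ncn(Cc3ccccc3)c12` has a different core; how the two cores differ is not broken down here. In this assay compound 3 gives 6%, level with compounds 1 and 2 within the scatter. Compound 4 `Fc1ccc(Cn2cnc3ncnc(Cl)c32)cc1` carries the same change as compound 2, (fluoro in place of hydrogen on an aromatic carbon), at a place described in the same words. Within the data shown here, because the only measured instance of this change is no change at the digits printed from compound 1 to compound 2 (within the scatter), the step from compound 3 to compound 4 is expected to be no change at the digits printed from compound 3 to compound 4 (within the scatter). In this assay compound 4 is therefore estimated at 6%, expected to fall between -5% and 18%.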

Compound 4, a percentage reported as inhibition, at one concentration (the size of the read-out at that concentration, not a potency): 7%
Estimate against measurement, compound 4: 1 percentage points below; the measured number falls inside the stated range.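

On the second core, fluoro in place of hydrogen on an aromatic carbon gives a number 1 percentage points higher from compound 3 to compound 4 (within the scatter). Set beside the first core, the two steps agree in this assay: the same change on two cores in this assay, no change at the digits printed (within the scatter) from compound 1 to compound 2 and a number 1 percentage points higher (within the scatter) from compound 3 to compound 4, 1 percentage points apart, within the scatter of two such steps. This shows that the change leaves the reading flat on both cores, but with all four compounds level it does not show whether the change would carry over to a compound whose reading stands clear of these values, and two cores make no rule for the series.

The compounds shown leave open whether an amine or a carboxylic acid in place of the fluoro would move the reading on either core. They also leave open what a longer chain would do in place of the chloro of compounds 3 and 4.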